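Series notes: chloro replacing hydrogen on the aryl of compound 2

This account rests on a few compounds, and the source may have more. Where it says the series, first, only, none or still open, it means among the compounds named here.

Compound 2 `Cc1ccc(C(=O)N/N=C/c2ccccc2)c(O)c1` gives 53900 nM in a functional assay (Mus musculus, strain BALB/C) for inhibition, read by MTT assay, with stated times of 24 h and 72 h; on this read-out higher numbers stand for weaker inhibition and lower numbers for stronger inhibition; among the measured numbers it stands highest, with compound 3 as the nearest neighbour. Compound 1 `COc1ccc(/C=N/NC(=O)c2ccc(C)cc2O)cc1` reaches only the assay limit, > 100000 nM, in this assay; that is a limit, not a number (the limit of > 100000 nM in this assay, at which 1 of the 3 values shown sits). Compound 3 `Cc1ccc(C(=O)N/N=C/c2ccccc2O)c(O)c1` gives 1020 nM in this assay.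

Two measured steps exist. The loss of methoxy on the aryl ring, an at least 1.8-fold lower number from compound 1 to compound 2 (0.26 log units; that floor lies within the scatter), is a step whose floor lies within the scatter. The gain of hydroxy on that ring, a 53-fold lower number from compound 2 to compound 3 (1.72 log units; beyond the scatter), is large and beyond the scatter.

Compound 4 `Cc1ccc(C(=O)N/N=C/c2cccc(Cl)c2)c(O)c1` differs from compound 2 by chloro in place of hydrogen on an aromatic carbon. The entering chloro brings 0 hydrogen-bond donors and 0 hydrogen-bond acceptors, so the hydroxy step of compound 3 is not the closer precedent; the methoxy step from compound 1 to compound 2, a substituent swap on the same ring, is. On that basis no step beyond the scatter is expected from compound 2 to compound 4, the estimated step being a 1.3-fold lower number from compound 2 to compound 4 (0.13 log units; within the scatter).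

Compound 4 is therefore estimated at 40000 nM in this assay, within 15000 nM to 110000 nM.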

Compound 4, half-maximal inhibitory concentration: 24400 nM
Compound 4: the middle estimate sits 1.6-fold (0.21 log units) above what was measured; measured number inside the range.
By their numbers in this assay, from the lowest: compound 3; then compound 4; then compound 2. At a limit, above all of these: compound 1.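

In this assay, going by these compounds alone, chloro meta to a large group gives the first measured step at this position, a 2.2-fold lower number from compound 2 to compound 4 (0.34 log units; beyond the scatter), and it is modest but beyond the scatter. Within the data shown here, the earlier compounds showed a large step for hydroxy, a 53-fold lower number from compound 2 to compound 3 (1.72 log units; beyond the scatter), and a step for the loss of methoxy whose floor lies within the scatter, an at least 1.8-fold lower number from compound 1 to compound 2 (0.26 log units; that floor lies within the scatter); the new step shows that an entering group with 0 hydrogen-bond donors and 0 hydrogen-bond acceptors can also lower the number beyond the scatter on this aromatic ring, though hydroxy remains the only large step. Nothing at hand gives a measured property that would account for the chloro step.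

Going by these compounds, it remains open whether this modest step belongs to chloro itself or would follow from other substituents at the same place, and a bromo, an amine or a carboxylic acid there would bear on that question. Compound 3 and compound 4 differ in more than one place, so the shown compounds also leave open how the hydroxy and chloro steps would combine in one structure.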